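This account rests on a few compounds, and the source may have more. Where it says the series, first, only, none or still open, it means among the compounds named here.

Compound 1 `COc1ccc(C2CC(c3ccc4ccccc4c3)=NN2C2=NC(=O)/C(=C3\C(=O)Nc4ccccc43)S2)cc1`: 360 nM
Compound 2 `COc1ccc(C2=NN(C3=NC(=O)/C(=C4\C(=O)Nc5ccc(Br)cc54)S3)C(c3ccc(Cl)cc3)C2)cc1`: 180 nM
Compound 3 `COc1ccc(-c2cc(-c3ccc(Cl)cc3)n(C3C(=O)Nc4ccc(Br)cc43)n2)cc1`: 7650 nM

All three compounds were tested in a functional assay on cells (Cancer cell lines, Homo sapiens) for cytotoxicity, read by sulforhodamine B assay, with a stated time of 48 h; on this read-out lower numbers stand for stronger inhibition of growth and higher numbers for weaker inhibition of growth. Compound 3 gives the highest number of the three, which on this read-out means the weakest inhibition of growth. Compound 1 lies nearest to it, and even that gap is beyond the usual scatter of repeated measurements. Compound 2 lies furthest from compound 3, by a gap that is also beyond the scatter. Compound 3 therefore stands clearly apart from the other two as the weaker inhibitor of growth.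

Compound 4 `COc1ccc(-c2cc(-c3ccc(Cl)cc3)n(C3C(=O)Nc4ccc(Cl)cc43)n2)cc1` differs from compound 3 in a single place: chloro in place of bromo on an aromatic carbon. For the measured compounds named here, no measured pair in this set makes the same exchange, so there is no directly comparable step to draw on. The swap keeps the count of heavy atoms, donors and acceptors unchanged, and nothing in the data points to a large shift in either direction. The step from compound 3 to compound 4 is expected to be a 1.0-fold higher number from compound 3 to compound 4 (0.02 log units; within the scatter), within the scatter and without a clear direction. Compound 4 is estimated at 8000 nM, with a likely range from 3500 nM to 18000 nM.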

Compound 4, concentration for 50% growth inhibition: 6490 nM
Estimate against measurement, compound 4: 1.2-fold (0.09 log units) above; the measured number falls inside the stated range.
By their numbers in this assay, from the lowest: compounds 2 and 1 (each within the scatter of the next); then compounds 4 and 3 (each within the scatter of the next).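

In this assay, putting chloro in place of bromo on an aromatic carbon of the six-membered ring gives a 1.2-fold lower number from compound 3 to compound 4 (0.07 log units; within the scatter), so at this position the two halogens cannot be told apart by their effect on growth inhibition. For the compounds shown here, the earlier compounds could not show this, as compounds 1, 2 and 3 all differ from one another in more than one place, and this is the first step in the set where a single group is exchanged and everything else stays the same. The data hold no separate measurement that would say why the exchange leaves the reading within the scatter.

Going by these compounds, only two halogens have been compared at this position, so it remains open whether a group of a different kind there, such as an amine, a nitrile or a carboxylic acid, would move the number beyond the scatter. On these data alone, it is also open whether the same exchange of bromo for chloro would read alike on the core of compound 2, which carries bromo on a different shared core and gives a much lower number.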